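Capping the Free Hydroxy Group of a Dinitrate Ester

This account rests on a few compounds, and the source may have more. Where it says the series, first, only, none or still open, it means among the compounds named here.

Measured in a functional assay on SKBR cells (Homo sapiens) for cytotoxicity, read by resazurin assay, with a stated time of 72 h; on this read-out higher numbers stand for weaker inhibition and lower numbers for stronger inhibition:
compound 1 `O=C(/C=C/c1ccc(OCCCCO[N+](=O)[O-])c(O)c1)OCCCCO[N+](=O)[O-]`: 3230 nM
compound 2 `COc1cc(/C=C/C(=O)Oc2ccc(OCc3c(-c4ccccc4)no[n+]3[O-])cc2)ccc1O`: 11000 nM

Of these two compounds, compound 1 has the lower number, and the gap up to compound 2 lies beyond the scatter. Compound 3 `COc1cc(/C=C/C(=O)OCCCCO[N+](=O)[O-])ccc1OCCCCO[N+](=O)[O-]` has not yet been measured. It departs from compound 1 by hydroxy to methoxy, that is, methyl in place of hydrogen on an oxygen on an aromatic ring. Within the data shown here, no measured pair shows this change, so the expectation stays loose. In this assay, a small weakening is expected, an estimated 1.5-fold higher number from compound 1 to compound 3 (0.19 log units; within the scatter). The estimated value for compound 3 is 5000 nM, with an expected range of 1800 nM to 14000 nM.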

Compound 3, half-maximal inhibitory concentration: > 50000 nM
Compound 3: no number, only a limit (the forecaster's own chance of this, stated with the estimate: 3%); middle value at least 10-fold (1.00 log units) from the limit.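

Methyl in place of hydrogen on an oxygen on an aromatic ring gives an at least 15-fold higher number from compound 1 to compound 3 (1.18 log units; beyond the scatter) in this assay, the first view of this change in the series. A change of one heavy atom at this place is thus enough for a large loss of cytotoxicity. For compound 3 the reading is a limit of the assay and not a number: the limit of > 50000 nM in this assay, at which 1 of the 3 values shown sits.

The compounds shown leave open how an ethyl, an acetyl or an amine at this place would read. They also leave open whether this step would recur on another core.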